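Aryl replacement at the biaryl position of compound 2

The source may hold more compounds than are shown below. What is called first, only, known or untested is meant among the compounds shown, and "the series" means these compounds.

Compound 1 `CC(Oc1ccccc1-c1ccc([N+](=O)[O-])cc1)C1=NCCN1`: in a functional assay on CHO cells for agonist activity at Alpha-2C adrenergic receptor (Homo sapiens) (a lower number here means a smaller maximal response, a higher number a larger maximal response), compound 1 gives < 0.3, which is a limit of the assay, not a number.
Compound 2 `Cc1ccc(-c2ccccc2OC(C)C2=NCCN2)cc1`: in this assay compound 2 gives 0.46.

Within the data shown here, compound 2 thus holds the only number in this assay; the other value is a limit (the limit of < 0.3 in this assay, at which 1 of the 2 values shown sits). Compound 3 `CC(Oc1ccccc1-c1cccnc1)C1=NCCN1` differs from compound 2 by pyridin-3-yl in place of 4-methylphenyl on an aromatic carbon. Among the measured compounds shown here, the one measured step, a number at least 0.16 higher from compound 1 to compound 2 (beyond the scatter), concerns a substituent exchange on that aryl ring and does not bear directly on replacing the ring itself, so no direction is established. Compound 3 is expected to show a step a number 0.080 lower from compound 2 to compound 3 (within the scatter), within or just beyond the scatter. The estimate for compound 3 is 0.38, between 0.18 and 0.58.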

Compound 3, intrinsic activity: the largest response reached, as a fraction of the reference agonist's: 1
Estimate against measurement, compound 3: 0.62 below, outside the stated range (above it).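

Exchanging the whole aryl ring at this position, and not only a substituent on it, changes the maximal response in this assay: pyridin-3-yl in place of 4-methylphenyl gives a number 0.54 higher from compound 2 to compound 3 (beyond the scatter). This step is large, and it shows that a six-membered aromatic ring with a hetero atom is tolerated here without loss of response. The value of compound 1 remains a limit, not a number: the limit of < 0.3 in this assay, at which 1 of the 3 values shown sits.

The compounds shown do not separate the entering ring nitrogen from the leaving methyl. An unsubstituted phenyl or a pyridin-4-yl group at this position would bear on that question.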